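Methyl on the urea nitrogen of compound 1

The source may hold more compounds than are shown below. What is called first, only, known or untested is meant among the compounds shown, and "the series" means these compounds.

Among the measured compounds shown here, compound 1 `CN(CC#CCN1CCCC1)C(N)=O` is the weaker of the two measured members: in an assay on ileum with muscarinic acetylcholine receptor M3 (Cavia porcellus) as the target (on this read-out lower numbers stand for tighter binding and higher numbers for weaker binding), compound 1 gives 49000 nM, while compound 2 `CC(C#CCN1CCCC1)N(C)C(N)=O` gives 710 nM. For the measured compounds named here, the one measured step, a 69-fold lower number from compound 1 to compound 2 (1.84 log units; beyond the scatter), concerns a methyl on the chain carbon, not the urea end. Compound 3 `CNC(=O)N(C)CC#CCN1CCCC1` differs from compound 1 by methyl in place of hydrogen on an amide-type nitrogen, on an amide-type nitrogen whose other neighbour is the carbonyl carbon. Going by the values given here, no measured step bears directly on this change, so only a modest shift in this assay is expected. The estimated step of a 1.6-fold lower number from compound 1 to compound 3 (0.21 log units; within the scatter) is small, and compound 3 is expected to give 30000 nM, within 8000 nM to 120000 nM.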

Compound 3, dissociation constant: 26400 nM
Estimate against measurement, compound 3: 1.1-fold (0.06 log units) above, within the range that was stated.
By their numbers in this assay, from the lowest: compound 2; then compounds 3 and 1 (each within the scatter of the next).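

In this assay, methyl in place of hydrogen on an amide-type nitrogen whose other neighbour is the carbonyl carbon gives a 1.9-fold lower number from compound 1 to compound 3 (0.27 log units; within the scatter), so the urea end takes this methyl with the two values remaining within the scatter. Among the compounds shown here, the only earlier step, a 69-fold lower number from compound 1 to compound 2 (1.84 log units; beyond the scatter), concerned the chain carbon and is beyond the scatter, so the two methyl positions read differently here. No evidence at hand accounts for either result.

Going by these compounds, whether an ethyl group or a longer chain on this nitrogen reads the same stays open. So does whether this methyl, combined with the methyl on the chain carbon, keeps the value of compound 2.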